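Notes on a crotonamide-type change in an anilinopyrimidine series

The compounds below may be only part of what the source reports. "The series", "measured", "known", "first", "only" and "open" are said of these compounds alone.

Three members of this series have numbers in a functional assay on HepG2 cells (Homo sapiens) for antiproliferative activity, read by MTT assay, with a stated time of 72 h; a lower number here means a stronger inhibitor, a higher number a weaker inhibitor. Compound 1 `CC/C=C\C(=O)Nc1cc(Nc2nc(C)cc(-c3cn(C)c4ccccc34)n2)c(OC)cc1N(C)CCN(C)C` gives 2050 nM. Compound 2 `CC/C=C\C(=O)Nc1cc(Nc2nccc(-c3cn(C)c4ccc(F)cc34)n2)c(OC)cc1N(C)CCN(C)C` gives 5290 nM. Compound 3 `C=CC(=O)Nc1cc(Nc2nc(C)cc(-c3cn(C)c4ccc(F)cc34)n2)c(OC)cc1N(C)CCN(C)C` gives 4280 nM, which is the second highest of the three numbers; it sits within the scatter of compound 2 and is beyond the scatter on the higher side of compound 1. Going by the values given here, compound 1 and compound 2 each carry the (but-1-en-1-yl)carbonyl group, compound 3 the vinylcarbonyl group; none of these pairs differs in only one place, so no single-change step is available.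

Compound 4 `CC/C=C\C(=O)Nc1cc(Nc2nc(C)cc(-c3cn(C)c4ccc(F)cc34)n2)c(OC)cc1N(C)CCN(C)C` differs from compound 3 by but-1-en-1-yl in place of vinyl on a carbonyl carbon. Compound 1 and compound 2, which already carry the (but-1-en-1-yl)carbonyl group, give numbers on both sides of compound 3, so no direction beyond the scatter is expected for this change; the step from compound 3 to compound 4 is estimated as a 1.2-fold lower number from compound 3 to compound 4 (0.09 log units; within the scatter). Compound 4 is expected to give about 3500 nM in this assay, with a range of 1500 nM to 8000 nM.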

Compound 4, half-maximal inhibitory concentration: 11000 nM
The estimate for compound 4 lay 3.1-fold (0.50 log units) below the measured number; measured number above the stated range.
By their numbers in this assay, from the lowest: compound 1; then compounds 3 and 2 (each within the scatter of the next); then compound 4.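

In this assay, but-1-en-1-yl in place of vinyl on a carbonyl carbon gives a 2.6-fold higher number from compound 3 to compound 4 (0.41 log units; beyond the scatter) and so does not leave the number unchanged at this position. With the (but-1-en-1-yl)carbonyl group held constant, methyl in place of hydrogen on an aromatic carbon gives a 2.1-fold higher number from compound 2 to compound 4 (0.32 log units; beyond the scatter) and fluoro in place of hydrogen on an aromatic carbon gives a 5.4-fold higher number from compound 1 to compound 4 (0.73 log units; beyond the scatter) in the same direction, so compound 4 stands apart from all three of its single-change neighbours. No measurement shown accounts for these steps.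

On these data alone, whether the vinyl to but-1-en-1-yl step keeps its size on a core lacking the fluoro or methyl group remains open. So does the outcome on this carbonyl carbon for a longer chain or for a chain carrying an amine.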